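The source may report more compounds than this note shows. Statements on the series, on what has been measured and on what is new or still open speak of the compounds shown alone.

Within the data shown here, compound 1 `COc1ccc(-c2nn(-c3ccccc3)cc2C(=O)NOCc2ccccc2)cc1` and compound 2 `COc1ccc(-c2nn(-c3ccccc3)cc2C(=O)NOCc2ccccc2Cl)cc1` are the two measured members. In a functional assay on MCF7 cells (Homo sapiens) for antiproliferative activity, read by MTT assay, with a stated time of 48 h, in the presence of a further agent that is not named here (on this read-out lower numbers stand for stronger inhibition of growth and higher numbers for weaker inhibition of growth), compound 1 gives 2770 nM and compound 2 gives 3730 nM. Among the measured compounds shown here, the two numbers lie within the scatter of each other: the step of a 1.3-fold higher number from compound 1 to compound 2 (0.13 log units; within the scatter) is the only measured step in hand, and it leaves the read-out unchanged in practical terms. Compound 3 `O=C(NOCc1ccccc1Cl)c1cn(-c2ccccc2)nc1-c1ccc(Cl)cc1` is not yet measured. It differs from compound 2 by chloro in place of methoxy on an aromatic carbon. For the measured compounds named here, no measured step touches this ring of compound 2; the single known step, chloro in place of hydrogen on the other aromatic ring, was within the scatter and gives no direct guide here. Going by the values given here, with only that neighbouring step as precedent, the expectation for compound 3 in this assay is a number near that of compound 2. The expected step is a 1.1-fold lower number from compound 2 to compound 3 (0.03 log units; within the scatter), that is, none beyond the scatter. The estimate for compound 3 is 3500 nM, in the range 1500 nM to 9000 nM.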

Compound 3, concentration for 50% growth inhibition: 16100 nM
Estimate against measurement, compound 3: 4.6-fold (0.66 log units) below, outside the stated range (above it).
By their numbers in this assay, from the lowest: compounds 1 and 2 (each within the scatter of the next); then compound 3.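

Among these compounds, the change from 4-methoxyphenyl to 4-chlorophenyl gives a 4.3-fold higher number from compound 2 to compound 3 (0.64 log units; beyond the scatter) in this assay, the first step beyond the scatter, whereas a 1.3-fold higher number from compound 1 to compound 2 (0.13 log units; within the scatter) on the other aromatic ring left the read-out unchanged in practical terms. The group at this place, para to a large group, therefore bears on the read-out, and here chloro goes with weaker inhibition of growth than methoxy, on the evidence of this single pair. No measurement at hand accounts for this step.

Still open, on these data alone, is whether the same exchange gives a step of similar size without the chloro on the other ring, on the frame of compound 1. Also open, as far as these compounds go, is how a hydroxy, methyl, fluoro or dimethylamino group would read at this place.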